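The source may hold more compounds than are shown below. What is called first, only, known or untested is meant among the compounds shown, and "the series" means these compounds.

Measured so far, in a functional assay on PC-3 cells (Homo sapiens) for inhibition, read by sulforhodamine B assay, with a stated time of 48 h; on this read-out higher numbers stand for weaker inhibition of growth and lower numbers for stronger inhibition of growth:
- compound 1 `Clc1ccc(Cn2cc(CCCOc3cccc4cccnc34)nn2)cc1`: 3.6 ug/mL
- compound 2 `Clc1ccc(Br)cc1Cn1cc(CCCOc2cccc3cccnc23)nn1`: 8.2 ug/mL

Among the measured compounds shown here, compound 2 gives the highest of the two numbers seen so far, meaning the weakest growth inhibition; its only neighbour is compound 1, which sits a 2.3-fold higher number from compound 1 to compound 2 (0.36 log units; beyond the scatter) below it. Compound 3 `c1ccc(Cn2cc(CCCOc3cccc4cccnc34)nn2)cc1` has not yet been tested. It differs from compound 2 in one place: phenyl in place of 5-bromo-2-chlorophenyl on a saturated chain carbon bound to an aromatic nitrogen. For the measured compounds named here, the only measured step that speaks to this site is the one from compound 1 to compound 2, where the number rose a 2.3-fold higher number from compound 1 to compound 2 (0.36 log units; beyond the scatter), so exchanging one halogen pattern for another changed the result modestly. Going by the values given here, compound 3 carries no halogen on that ring at all, which no measured compound shows, so the direction is uncertain. Among the compounds with values here, compound 3 is expected to land close to the earlier compounds, with an estimated step of a 1.8-fold lower number from compound 2 to compound 3 (0.26 log units; within the scatter). The estimate for compound 3 in this assay is 4.5 ug/mL, within a range of 1.8 ug/mL to 11 ug/mL.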

Compound 3, concentration for 50% growth inhibition: 16.8 ug/mL
Compound 3: middle estimate off by 3.7-fold (0.57 log units), on the low side; measured number above the stated range.
By their numbers in this assay, from the lowest: compound 1; then compound 2; then compound 3.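

In this assay, the bare benzyl group turns out to be the poorest of the three at this position: removing the single chloro gives a 4.7-fold higher number from compound 1 to compound 3 (0.67 log units; beyond the scatter), and replacing 5-bromo-2-chlorobenzyl with benzyl gives a 2.0-fold higher number from compound 2 to compound 3 (0.31 log units; beyond the scatter), both pointing to weaker inhibition of growth. The earlier step compared only one halogen pattern with another, whereas these steps show that both halogen-bearing rings do better than the ring with none, and no compound shown goes against this. Nothing available explains why this ring responds in this way.

Whether the chloro or the bromo accounts for the advantage of compound 2 over compound 3 remains open. So does whether a methoxy group or an amine on the same ring could match a halogen.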